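Extending the core of compound 3 with an arylamino group

A few compounds are considered here, and "the series" means these few. Any claim that something is new, unique, unknown or untested is made for them only; others in the source may bear on it.

Of the compounds shown here, three share one core and have been tested in a functional assay on the whole organism (strain albino) for inhibition, with Rattus norvegicus as the target, read by paw edema, with stated times of 1 h and 0.5 h, at a dose of 100 mg/kg by the oral route; on this read-out lower numbers stand for less inhibition and higher numbers for more inhibition at the one dose given (going by the name of the read-out). Compound 1 `N#Cc1c(-c2ccc(Cl)cc2)nc(SCC(=O)Nn2c(COc3ccc(Cl)cc3Cl)nc3ccccc3c2=O)[nH]c1=O` gives 61.5%. Compound 2 `N#Cc1c(Cl)nc(SCC(=O)Nn2c(COc3ccc(Cl)cc3Cl)nc3ccccc3c2=O)nc1-c1ccccc1` gives 53.9%. Compound 3 `N#Cc1c(Cl)nc(SCC(=O)Nn2c(COc3ccc(Cl)cc3Cl)nc3ccccc3c2=O)nc1-c1ccc(O)cc1` gives 67.3%, the highest of the three numbers, though its gap to compound 1 is within the scatter; only its gap to compound 2 is beyond it. Within the data shown here, the one step between compounds differing in a single place is a number 13.4 percentage points higher from compound 2 to compound 3 (beyond the scatter).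

Compound 4 `N#Cc1c(Nc2ccc(Cl)cc2)nc(SCC(=O)Nn2c(COc3ccc(Cl)cc3Cl)nc3ccccc3c2=O)nc1-c1ccc(O)cc1` is the next candidate. It differs from compound 3 in one place: (4-chlorophenyl)amino in place of chloro on an aromatic carbon. Among the measured compounds shown here, no measured step covers this kind of change: the only single-place step, from compound 2 to compound 3, concerns a hydroxy group at another place, so it gives no direct guide. In the absence of such a step, the expectation is that compound 4 will stay near compound 3, with the step from compound 3 to compound 4 expected as a number 3.3 percentage points lower from compound 3 to compound 4 (within the scatter), not beyond the scatter in either direction. For compound 4 in this assay the estimate is 64%, with a range from 48% to 78%.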

Compound 4, a percentage reported as inhibition, in the whole organism at one dose (the size of the read-out at that dose, not a potency): 65.4%
For compound 4 the middle estimate is 1.4 percentage points below the measured one; the measured number falls inside the stated range.
By their numbers in this assay, from the lowest: compounds 2, 1, 4 and 3 (each within the scatter of the next, the first and the last beyond it).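

Replacing chloro with (4-chlorophenyl)amino on the aromatic carbon ortho to a cyano group gives a number 1.9 percentage points lower from compound 3 to compound 4 (within the scatter) in this assay, so at this single dose the read-out does not separate the two groups. Among these compounds, this is the first view of this position, as the earlier step concerned a hydroxy group at another place. It shows that a group of 8 heavy atoms, bringing an extra aromatic ring, a hydrogen-bond donor and a hydrogen-bond acceptor, can take the place of a single chlorine atom without a difference beyond the scatter. Nothing measured here explains this outcome.

The compounds shown leave open which part of the new group matters, since the linking nitrogen and the chlorinated ring enter together: a plain amino group, a morpholine or an unsubstituted phenylamino group at this position would begin to pull those parts apart. As far as these compounds go, it also remains open whether the hydroxy group on the 4-hydroxyphenyl ring still makes a difference when (4-chlorophenyl)amino is present, as it did alongside chloro in the step of a number 13.4 percentage points higher from compound 2 to compound 3 (beyond the scatter), which lies beyond the scatter.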